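Swapping thiazolyl for methylpyrazolyl in a hydrolase inhibitor series

This account rests on a few compounds, and the source may have more. Where it says the series, first, only, none or still open, it means among the compounds named here.

Going by the values given here, compound 3 `Cn1nc2c(=O)n(CC3(O)CCN(Cc4ccc(-c5cncs5)cc4Cl)CC3)cnc2c1-c1ccc(CN)cc1` gives 117 nM in an assay on isolated protein for inhibition of ubiquitin carboxyl-terminal hydrolase 7 (Homo sapiens), with stated times of 30 min and 2 h (a higher number here means a weaker inhibitor, a lower number a stronger inhibitor), the highest of the three numbers measured so far: compound 1 `Cn1nc2c(=O)n(CC3(O)CCN(Cc4ccc(-c5ccco5)cc4Cl)CC3)cnc2c1-c1ccc(CO)cc1` gives 42.5 nM and compound 2 `CC(=O)NCc1ccc(-c2c3ncn(CC4(O)CCN(Cc5ccc(-c6ccco6)cc5Cl)CC4)c(=O)c3nn2C)cc1` gives 46.1 nM. Compound 4 `Cn1cc(-c2ccc(CN3CCC(O)(Cn4cnc5c(-c6ccc(CN)cc6)n(C)nc5c4=O)CC3)c(Cl)c2)cn1` differs from compound 3 in one place: 1-methyl-1H-pyrazol-4-yl in place of 1,3-thiazol-5-yl on an aromatic carbon. Among the compounds with values here, the only measured step, a 1.1-fold higher number from compound 1 to compound 2 (0.04 log units; within the scatter), alters a different part of the molecule and so offers no direct precedent for this exchange; nothing measured here speaks to replacing one five-membered aromatic ring with two hetero atoms by another at this position. Compound 4 is therefore expected to stay within the scatter of its neighbour, the expected step being no change at the digits printed from compound 3 to compound 4 (within the scatter). The estimate for compound 4 is 117 nM, ranging from 55 nM to 250 nM.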

Compound 4, half-maximal inhibitory concentration: 291 nM
For compound 4 the middle estimate is 2.5-fold (0.40 log units) below the measured one, and the stated range ends below it.
By their numbers in this assay, from the lowest: compounds 1 and 2 (each within the scatter of the next); then compound 3; then compound 4.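

At this position the ring is not freely exchangeable in this assay: 1-methyl-1H-pyrazol-4-yl in place of 1,3-thiazol-5-yl brings a 2.5-fold higher number from compound 3 to compound 4 (0.40 log units; beyond the scatter), a modest step, although both are five-membered aromatic rings with 2 hetero atoms and the same counts of hydrogen-bond donors and acceptors. No measurement is available that would account for this step. The compounds shown leave open whether the step follows from the pyrazole ring or from its methyl group, and how an unmethylated pyrazolyl or a pyridyl would stand at this position.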